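Trifluoromethyl for trifluoromethoxy on two related cores

A few compounds are considered here, and "the series" means these few. Any claim that something is new, unique, unknown or untested is made for them only; others in the source may bear on it.

All numbers below come from a functional assay on T47D cells (Homo sapiens) for cytotoxicity, read by MTT assay, with a stated time of 2 days; on this read-out lower numbers stand for stronger inhibition and higher numbers for weaker inhibition.

- compound 1 `Cc1ccc2nc(-c3cccc(C(F)(F)F)c3)[nH]c(=O)c2c1`: > 50000 nM
- compound 2 `Cc1ccc2nc(-c3cccc(OC(F)(F)F)c3)[nH]c(=O)c2c1`: > 50000 nM
- compound 3 `Cc1ccc2c(=O)[nH]c(-c3cccc(OC(F)(F)F)c3)nc2c1`: > 50000 nM

In this assay compound 1 gives > 50000 nM, which is a limit of the assay and not a number. In this assay compound 2 gives > 50000 nM, again a limit. In this assay compound 3 gives > 50000 nM, also a limit. Compound 1 and compound 2 share one core and differ only in trifluoromethyl in place of trifluoromethoxy on an aromatic carbon; the step that the two limits leave unreadable from compound 2 to compound 1 cannot be read, since both ends sit at the limit. Compound 2 and compound 3 have the same atoms joined differently, and the difference between the two cores is not broken down here. Compound 4 `Cc1ccc2c(=O)[nH]c(-c3cccc(C(F)(F)F)c3)nc2c1` has not been measured; it stands to compound 3 as compound 1 stands to compound 2, through (trifluoromethyl in place of trifluoromethoxy on an aromatic carbon), the same change at a place described in the same words.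

For the measured compounds named here, the only evidence on the series is the limit of > 50000 nM in this assay, at which 3 of the 3 values shown sit, so nothing indicates that either core or either group reaches a measurable number. Compound 4 is therefore expected to give a limit as well, an expected step that the limit leaves unreadable from compound 3 to compound 4 that rests on compound 2 and compound 1 both sitting at the limit of > 50000 nM in this assay, at which 3 of the 3 values shown sit. For compound 4 the estimate is 80000 nM, with an expected range from 30000 nM to 300000 nM.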

Compound 4, half-maximal inhibitory concentration: > 50000 nM
Compound 4 was reported as a limit; the forecaster's own chance of this, stated with the estimate: 85%; the middle value does not contradict the limit.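

In this assay compound 4 gives > 50000 nM as a limit of the assay and not a number. For the compounds shown here, compound 3 also sits at a limit, so the step from compound 3 to compound 4, trifluoromethyl in place of trifluoromethoxy, cannot be read, and this result yields no new step. The compounds shown leave open whether any group on either core reaches a measurable number in this assay at all.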